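The compounds below may be only part of what the source reports. "The series", "measured", "known", "first", "only" and "open" are said of these compounds alone.

The series starts from compound 1 `COc1ccc(C2CC(c3ccc4ccccc4c3)=NN2C2=NC(=O)/C(=C3\C(=O)Nc4ccccc43)S2)cc1`, which in a functional assay on cells (Cancer cell lines, Homo sapiens) for cytotoxicity, read by sulforhodamine B assay, with a stated time of 48 h (on this read-out higher numbers stand for weaker inhibition of growth and lower numbers for stronger inhibition of growth), gives 2470 nM. Compound 2 `COc1ccc(C2CC(c3ccc4ccccc4c3)=NN2C2=NC(=O)/C(=C3\C(=O)Nc4ccc(Br)cc43)S2)cc1` differs from compound 1 only by bromo in place of hydrogen on an aromatic carbon, and in this assay compound 2 gives 510 nM. The change produced a 4.8-fold lower number from compound 1 to compound 2 (0.69 log units; beyond the scatter).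

Compound 3 `CN(C)c1ccc(C2CC(c3ccccc3)=NN2C2=NC(=O)/C(=C3\C(=O)Nc4ccccc43)S2)cc1` belongs to the same family but carries a different core; the difference between the core of compound 1 and the core of compound 3 is not broken down here. In this assay compound 3 gives 34000 nM, the highest of the three numbers and therefore the weakest growth inhibition measured so far, with both of its gaps, to compound 1 and to compound 2, beyond the usual scatter.

Compound 4 `CN(C)c1ccc(C2CC(c3ccccc3)=NN2C2=NC(=O)/C(=C3\C(=O)Nc4ccc(Br)cc43)S2)cc1` has not yet been measured. It relates to compound 3 exactly as compound 2 relates to compound 1: the change is bromo in place of hydrogen on an aromatic carbon, and the surroundings of the place are described in the same words for both pairs, so the change is the same one. Only one prior instance of it exists among these compounds, in the pair from compound 1 to compound 2, and a single instance on a different core is a thin basis. Still, the expectation for compound 4 rests on that step, because a 4.8-fold lower number from compound 1 to compound 2 (0.69 log units; beyond the scatter) points toward a lower number; the step from compound 3 to compound 4 is estimated as a 4.5-fold lower number from compound 3 to compound 4 (0.66 log units; beyond the scatter). Compound 4 is therefore expected to give about 7500 nM in this assay, with a plausible range from 2500 nM to 22000 nM.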

Compound 4, concentration for total growth inhibition: 720 nM
Beside the measured number, compound 4's estimate is 10-fold (1.02 log units) above it; the whole stated range lies above it.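

In this assay, bromo in place of hydrogen on an aromatic carbon again went with a lower number, here a 47-fold lower number from compound 3 to compound 4 (1.67 log units; beyond the scatter), so the direction of the change held on both the core of compound 1 and the core of compound 3. For the compounds shown here, the size of the step did not carry over, and the gap between the two steps is larger than repeated measurements would explain: the same change on two cores in this assay, a 4.8-fold lower number (0.69 log units; beyond the scatter) from compound 1 to compound 2 and a 47-fold lower number (1.67 log units; beyond the scatter) from compound 3 to compound 4, 9.8-fold (0.99 log units) apart, beyond the scatter of two such steps This does not show what sets the size of the step, since the difference between the two cores is not broken down and only two pairs are available, so the result gives neither a reason for the larger step nor a rule for other cores.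

The compounds shown leave open whether another halogen, such as chloro or fluoro, or a small group such as methyl or methoxy, placed on the same aromatic carbon would follow the bromo compounds on either core. They also leave open whether the bromo step would keep its direction, and what size it would take, on cores carrying other groups, such as a carboxylic acid or a longer chain ending in an amine.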